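The compounds below may be only part of what the source reports. "The series", "measured", "known", "first", "only" and "open" are said of these compounds alone.

Compounds measured so far:
- Compound 1 `CCCN(CC1CC1)c1nc(C)nc2c1c(C)c(C)n2-c1c(C)cc(C)cc1C`: 2.3 nM
- Compound 2 `CCCCN(CCCCF)c1nc(C)nc2c1c(C)c(C)n2-c1c(C)cc(C)cc1C`: 10 nM

In an assay on cerebellum with corticotropin-releasing factor receptor 1 (Rattus norvegicus) as the target (a higher number here means a weaker inhibitor, a lower number a stronger inhibitor), compound 2 gives 10 nM, the higher of the two numbers, while compound 1 gives 2.3 nM. For the measured compounds named here, the single measured step, a 4.3-fold higher number from compound 1 to compound 2 (0.64 log units; beyond the scatter), replaced both arms of the amine at once, so it does not isolate either change. Compound 3 `Cc1cc(C)c(-n2c(C)c(C)c3c(N(CCCF)CC4CC4)nc(C)nc32)c(C)c1` differs from compound 2 in that ((cyclopropylmethyl)(3-fluoropropyl)amino in place of butyl(4-fluorobutyl)amino on an aromatic carbon). This change restores the cyclopropylmethyl arm of compound 1 and shortens the fluorinated chain, so compound 3 sits between compounds 1 and 2 in structure, closer to compound 1. On that basis a move back toward the lower number of compound 1 is expected, though the effect of the fluorine on the propyl arm is not separately known; the expected step is a 2.5-fold lower number from compound 2 to compound 3 (0.40 log units; beyond the scatter). Compound 3 is therefore estimated at 4 nM, within a range of 1.5 nM to 12 nM.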

Compound 3, inhibition constant: 30 nM
For compound 3 the middle estimate is 7.5-fold (0.88 log units) below the measured one; measured number above the stated range.
By their numbers in this assay, from the lowest: compound 1; then compound 2; then compound 3.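

In this assay, the propyl arm of compound 1 and the 3-fluoropropyl arm of compound 3 differ by a single fluoro in place of hydrogen, with the cyclopropylmethyl arm held constant, and that one change gives a 13-fold higher number from compound 1 to compound 3 (1.12 log units; beyond the scatter). The cyclopropylmethyl arm therefore does not by itself keep the number low on this aromatic carbon, and the exchange of both arms gives a 3.0-fold higher number from compound 2 to compound 3 (0.48 log units; beyond the scatter), which leaves compound 3 the weakest of the three. No evidence is available on what lies behind either step.

It remains open whether a fluoro at the end of the butyl chain in compound 2 costs as much as the fluoro on the propyl arm does, since no dibutylamino partner is among these compounds. From the compounds shown here alone, how a shorter 2-fluoroethyl arm or a hydroxyl at the end of the propyl arm would read also remains open.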